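This account rests on a few compounds, and the source may have more. Where it says the series, first, only, none or still open, it means among the compounds named here.

Compound 2, `CCc1c(C)n(C(=O)N2CCCCC2)oc1=O`, in an assay (strain Wistar) for inhibition of Hormone-sensitive lipase (Rattus norvegicus), read by spectrophotometry; a lower number here means a stronger inhibitor, a higher number a weaker inhibitor: 18 nM
Compound 1, `Cc1c(S(=O)(=O)c2ccc(Cl)cc2)c(=O)on1C(=O)N1CCCCC1`, in this assay: 35 nM

Compound 2 has the lowest of the two numbers shown, but compound 1 lies within the usual scatter of it, so no order between the two can be claimed. Compound 3, `Cc1c(C(C)(C)C)c(=O)on1C(=O)N1CCCCC1`, is not yet measured. It differs from compound 2 in one place: tert-butyl in place of ethyl on an aromatic carbon. For the measured compounds named here, no measured pair shows a change of this kind, so nothing here fixes its size; a step of about the scatter, in no clear direction, is expected. Compound 3 is estimated at 25 nM, with a range from 8 nM to 80 nM. The expected step is a 1.4-fold higher number from compound 2 to compound 3 (0.14 log units; within the scatter).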

Compound 3, half-maximal inhibitory concentration: 14 nM
The estimate for compound 3 lay 1.8-fold (0.25 log units) above the measured number; low and high end bracket the measured number.
By their numbers in this assay, from the lowest: compounds 3, 2 and 1 (each within the scatter of the next, the first and the last beyond it).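

In this assay, tert-butyl in place of ethyl on this aromatic carbon gives a 1.3-fold lower number from compound 2 to compound 3 (0.11 log units; within the scatter) and so lies within the scatter, which leaves compound 2 and compound 3 without an order. For the compounds shown here, this is the first step read at this position, and it shows that the four-carbon tert-butyl group is tolerated here as well as the two-carbon ethyl group. Still open, from the compounds shown here alone, is whether a phenyl ring, an amine or a carboxylic acid at this position would hold the number in the same range. No measurement at hand accounts for this result.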